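Two Weak Compounds and an Unmeasured Ring Swap

A few compounds are considered here, and "the series" means these few. Any claim that something is new, unique, unknown or untested is made for them only; others in the source may bear on it.

Measured compounds:
compound 1, `CCS(=O)(=O)N1CC2CCC(NC(=O)c3ccc(Cl)cc3Cl)C2C1`, > 10000 nM
compound 2, `Cn1cnc(S(=O)(=O)N2CC3CCC(NC(=O)c4ccccc4C(F)(F)F)C3C2)c1`, 112000 nM

Compound 1 returns only a limit in an assay on isolated protein for inhibition of sodium- and chloride-dependent glycine transporter 1 (Homo sapiens) (on this read-out lower numbers stand for stronger inhibition and higher numbers for weaker inhibition), namely > 10000 nM, which is a boundary of the assay rather than a number. Among the compounds with values here, compound 2 is thus the only compound with a real number in this assay, 112000 nM, and it stands alone on that scale. Compound 3, `Cn1cnc(S(=O)(=O)N2CC3CCC(NC(=O)c4ccc(Cl)cc4)C3C2)c1`, has not yet been measured. It differs from compound 2 in one place: 4-chlorophenyl in place of 2-(trifluoromethyl)phenyl on a carbonyl carbon. Within the data shown here, no step between two measured compounds exists to calibrate this change; the only other evidence is the limit of > 10000 nM in this assay, at which 1 of the 2 values shown sits, which allows no comparison. The step from compound 2 to compound 3 is therefore expected to be modest, a 2.2-fold lower number from compound 2 to compound 3 (0.35 log units; beyond the scatter), with no firm direction. Compound 3 is expected to give about 50000 nM in this assay, most likely between 10000 nM and 250000 nM, and it may again return only a limit.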

Compound 3, half-maximal inhibitory concentration: 1030000 nM
The estimate for compound 3 lay 21-fold (1.31 log units) below the measured number; measured number above the stated range.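

Within the data shown here, this is the first step between two measured compounds, and it shows that the group on the carbonyl carbon does affect the result in this assay. With the rest of the structure unchanged, putting 4-chlorophenyl in place of 2-(trifluoromethyl)phenyl gives a 9.2-fold higher number from compound 2 to compound 3 (0.96 log units; beyond the scatter) and so weaker inhibition, a change beyond the usual scatter of the measurement. Nothing shown here accounts for the direction or size of this step.

This single swap changes both the substituent and its place on the phenyl ring, so the effects of the two cannot be separated. Going by these compounds, it also remains open whether an unsubstituted phenyl, a pyridine ring or an aliphatic amine on the same carbonyl carbon would bring the number down, and by how much.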